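Changing the Sulfonamide Arm: What to Expect for Compound 4

The source may report more compounds than this note shows. Statements on the series, on what has been measured and on what is new or still open speak of the compounds shown alone.

Measured compounds:
Compound 1 `COc1ccc(S(=O)(=O)NCCCNc2nccc(-c3c(-c4cccc(F)c4)nc4sccn34)n2)cc1`: 8980 nM
Compound 2 `O=S(=O)(NCCNc1nccc(-c2c(-c3cccc(F)c3)nc3sccn23)n1)c1ccc(Cl)cc1`: 18600 nM
Compound 3 `O=C(NCCNc1nccc(-c2c(-c3cccc(F)c3)nc3sccn23)n1)c1ccc(C(F)(F)F)cc1`: 9260 nM

In a functional assay on SK-MEL-28 cells (Homo sapiens) for cytotoxicity, read by MTT assay (a higher number here means a weaker inhibitor, a lower number a stronger inhibitor), compound 2 gives the highest of the three numbers; compound 1 gives 8980 nM and compound 3 gives 9260 nM, both lower. Compound 4 `Cc1ccc(S(=O)(=O)NCCCNc2nccc(-c3c(-c4cccc(F)c4)nc4sccn34)n2)cc1` differs from compound 2 by (((4-methylphenyl)sulfonyl)amino)methyl in place of ((4-chlorophenyl)sulfonyl)amino on a saturated chain carbon, two bonds along the chain from a nitrogen on an aromatic ring. Among the measured compounds shown here, the only measured step on this arm, a 2.0-fold lower number from compound 2 to compound 3 (0.30 log units; within the scatter), stays within the scatter, while compound 1, which carries the longer chain with a sulfonyl arm, stands below compound 2 by more than the scatter. A modest downward step is therefore expected, a 2.0-fold lower number from compound 2 to compound 4 (0.29 log units; within the scatter). Compound 4 is estimated at 9500 nM, with a range from 4500 nM to 20000 nM.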

Compound 4, half-maximal inhibitory concentration: 9500 nM
Estimate against measurement, compound 4: no gap at the digits printed, within the range that was stated.
By their numbers in this assay, from the lowest: compounds 1, 3, 4 and 2 (each within the scatter of the next, the first and the last beyond it).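

In this assay, methyl in place of methoxy on an aromatic carbon gives a 1.1-fold higher number from compound 1 to compound 4 (0.02 log units; within the scatter), so on this longer sulfonyl arm the change stays within the scatter. The other step, a 2.0-fold lower number from compound 2 to compound 4 (0.29 log units; within the scatter), is also within the scatter, but it changes the chain and swaps the aromatic group together, so it cannot separate their contributions. No supporting data explain either step.

The compounds shown leave open whether a still longer chain, or an amine or carboxylic acid in place of the methyl, would move the number beyond the scatter.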